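This account rests on a few compounds, and the source may have more. Where it says the series, first, only, none or still open, it means among the compounds named here.

Measured in a functional assay on HT-29 cells (Homo sapiens) for inhibition, read by MTT assay, with a stated time of 2 days; a lower number here means a stronger inhibitor, a higher number a weaker inhibitor:
- compound 1 `Nc1cccc(/C=C/c2ccccc2)c1` gives 12.9 ug/mL
- compound 2 `COc1cccc(/C=C/c2cccc(O)c2)c1` gives 11.5 ug/mL

Compound 2 at 11.5 ug/mL stands within the scatter of compound 1, so neither can be ranked above the other. Compound 3 `COc1cccc(/C=C/c2cccc(N)c2)c1` differs from compound 2 in one place, an aromatic carbon meta to a large group, with amino in place of hydroxy (amino in place of hydroxy on an aromatic carbon). Among the compounds with values here, no measured pair shows this change, so no step beyond the scatter is expected in this assay in either direction. The expected result is a 1.0-fold higher number from compound 2 to compound 3 (0.02 log units; within the scatter) and would lie within the scatter. For compound 3 the estimated value is 12 ug/mL with an expected range from 6 ug/mL to 24 ug/mL.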

Compound 3, half-maximal inhibitory concentration: 19.6 ug/mL
For compound 3 the middle estimate is 1.6-fold (0.21 log units) below the measured one, and the stated range covers the measured number.
By their numbers in this assay, from the lowest: compounds 2, 1 and 3 (each within the scatter of the next).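

In this assay, within the data shown here, amino in place of hydroxy on an aromatic carbon meta to a large group gives a 1.7-fold higher number from compound 2 to compound 3 (0.23 log units; within the scatter), so at this position the exchange shows no step that can be told from the scatter. Methoxy in place of hydrogen on an aromatic carbon gives a 1.5-fold higher number from compound 1 to compound 3 (0.18 log units; within the scatter), which likewise cannot be told from the scatter. No supporting measurement bears on either step.

Still open, on these data alone, is whether a carboxylic acid at this position, or ethoxy in place of methoxy, would give a step beyond the scatter.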